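The compounds below may be only part of what the source reports. "The series", "measured", "known", "first", "only" and "open" are said of these compounds alone.

Of the compounds shown here, three of one family have been measured. Compound 1 `CC(C)=CCC/C(C)=C/CC/C(C)=C/C(=O)NC(=N)N` gives 22000 nM in a functional assay on MCF7 cells (Homo sapiens) for inhibition, read by MTT assay, with a stated time of 72 h; on this read-out lower numbers stand for stronger inhibition of growth and higher numbers for weaker inhibition of growth. Among the measured compounds shown here, compound 2 `CC(C)=CCC/C(C)=C/CC/C(C)=C/C(=O)NC(=N)NC(=O)C=C(C)C` gives 23400 nM, and the one step between measured compounds, a 1.1-fold higher number from compound 1 to compound 2 (0.03 log units; within the scatter), is within the scatter. Compound 3 `CC(C)=CCC/C(C)=C/C(=O)NC(=N)NC(=O)/C=C(\C)CCC=C(C)C` gives 42400 nM; its number is the largest of the three, but its gaps to compound 2 and to compound 1 are both within the scatter, so nothing separates these three on this read-out.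

Compound 4 `CC(C)=CCC/C(C)=C/CC/C(C)=C/C(=O)NC(=N)NC(=O)/C=C(\C)CCC=C(C)C` is the next member, and it differs from compound 3 by 3-methylbut-2-en-1-yl in place of hydrogen on a saturated chain carbon bound to a double-bonded chain carbon. For the measured compounds named here, no measured step touches this part of the molecule: the only step known, from compound 1 to compound 2, changes the amine nitrogen instead and was within the scatter. With nothing in the data pointing to a change in either direction, the step from compound 3 to compound 4 is expected to be a 1.2-fold lower number from compound 3 to compound 4 (0.08 log units; within the scatter), within the scatter. Compound 4 is therefore estimated at 35000 nM, with a plausible range from 15000 nM to 80000 nM.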

Compound 4, concentration for 50% growth inhibition: 51200 nM
Compound 4: middle estimate off by 1.5-fold (0.17 log units), on the low side, and the stated range covers the measured number.
By their numbers in this assay, from the lowest: compounds 1, 2, 3 and 4 (each within the scatter of the next, the first and the last beyond it).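

Adding 3-methylbut-2-en-1-yl on a saturated chain carbon bound to a double-bonded chain carbon does not give one fixed result in this assay. The addition stays within the scatter in a 1.2-fold higher number from compound 3 to compound 4 (0.08 log units; within the scatter), whereas a 2.2-fold higher number from compound 2 to compound 4 (0.34 log units; beyond the scatter) goes modestly beyond it, toward weaker inhibition of growth, and is the first listed step in this family to do so. Nothing measured here explains why the same addition reads differently in these two pairs.

The compounds shown carry only chains with double bonds at this position, so it remains open whether a fully saturated chain of the same length would read alike. As far as these compounds go, it is also open how a carboxylic acid or an amine in place of 3-methylbut-2-en-1-yl would read.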